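A few compounds are considered here, and "the series" means these few. Any claim that something is new, unique, unknown or untested is made for them only; others in the source may bear on it.

Measured compounds in a functional assay on Jurkat cells (Homo sapiens) for inhibition; on this read-out lower numbers stand for stronger inhibition and higher numbers for weaker inhibition:

compound 1, `CC(C)[C@H](NC(=O)COc1cccc2ccccc12)C(=O)N[C@@H](CC(=O)O)C(=O)CSc1nnnn1-c1ccccc1`, gives 153000 nM.
compound 2, `CC(C)[C@H](NC(=O)COc1cccc2ccccc12)C(=O)N[C@@H](CC(=O)O)C(=O)COc1ccccn1`, gives only a limit of the assay, > 200000 nM.
compound 3, `CC(C)[C@H](NC(=O)COc1cccc2ccccc12)C(=O)N[C@@H](CC(=O)O)C(=O)CSc1nccc(C(F)(F)F)n1`, gives only a limit of the assay, > 200000 nM.

Compound 3 stands at the assay limit, not at a number, and shares that position with compound 2 (the limit of > 200000 nM in this assay, at which 2 of the 3 values shown sit). Within the data shown here, compound 1 is the only compound of the three with a measured value, and all three sit at the weak end of this assay.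

Compound 4, `CC(C)[C@H](NC(=O)COc1cccc2ccccc12)C(=O)N[C@@H](CC(=O)O)C(=O)COc1[nH]cnc2nncc1-2`, differs from compound 3 as follows: a group of 10 heavy atoms (5 carbon, 4 nitrogen, 1 oxygen; one five-membered aromatic ring with 2 hetero atoms, one six-membered aromatic ring with 2 hetero atoms) in place of a group of 11 heavy atoms (5 carbon, 2 nitrogen, 3 fluorine, 1 sulfur; one six-membered aromatic ring with 2 hetero atoms), on a saturated chain carbon bound to a carbonyl carbon.

Steps that bear on this change: an at least 1.3-fold higher number from compound 1 to compound 3 (0.11 log units; that floor lies within the scatter), a step that the two limits leave unreadable from compound 2 to compound 3, and an at least 1.3-fold higher number from compound 1 to compound 2 (0.11 log units; that floor lies within the scatter), the last one also running toward an oxygen-linked aromatic group on the same chain carbon. None of these reads as a step beyond the scatter, and two of them end at the limit. Among the measured compounds shown here, no step in the set shows a move away from the limit, so compound 4 is expected to remain at or near it, with a step of a number no higher from compound 3 to compound 4 (the limit leaves the size open) expected in this assay. For compound 4 the estimate in this assay is 200000 nM, with a range from 100000 nM to 400000 nM, and a limit rather than a number is the likelier outcome.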

Compound 4, half-maximal inhibitory concentration: 161000 nM
The estimate for compound 4 lay 1.2-fold (0.09 log units) above the measured number; low and high end bracket the measured number.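

In this assay, compound 4 gives a measured value of 161000 nM, so an oxygen-linked aromatic group on the saturated chain carbon bound to a carbonyl carbon now has a readable number, which compound 2 could not provide. Even so, the steps to this number do not establish a gain: an at least 1.2-fold lower number from compound 3 to compound 4 (0.09 log units; that floor lies within the scatter), and an at least 1.2-fold lower number from compound 2 to compound 4 (0.09 log units; that floor lies within the scatter). Against the only other measured compound, a 1.1-fold higher number from compound 1 to compound 4 (0.02 log units; within the scatter), so the group in compound 4 and the (1-phenyl-1H-tetrazol-5-yl)sulfanyl group of compound 1 cannot be separated here.

Compound 2 and compound 3 remain limits, so their true distance from compound 4 stays open: the limit of > 200000 nM in this assay, at which 2 of the 4 values shown sit.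
From the compounds shown here alone, it also remains open whether an amine or a carboxylic acid on the same chain carbon would move the series away from the weak end of this assay.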